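This account rests on a few compounds, and the source may have more. Where it says the series, first, only, none or still open, it means among the compounds named here.

Among the compounds with values here, compound 1 `Nc1nc(NCc2cccs2)nc2sc(-c3ccco3)nc12` is one of two compounds measured in an assay on CHO cells for displacement of a labelled ligand from adenosine receptor A1 (Homo sapiens), read by scintillation counting, with a stated time of 90 min (on this read-out higher numbers stand for weaker inhibition and lower numbers for stronger inhibition), where compound 1 gives 12.5 nM, the lower of the two numbers. Compound 2 `Cc1ccc(-c2nc3c(N)nc(NCc4cccs4)nc3s2)o1` carries a methyl in place of hydrogen on an aromatic carbon and gives 71 nM; the step is a 5.7-fold higher number from compound 1 to compound 2 (0.75 log units; beyond the scatter). Compound 3 `Nc1nc(NCc2ccncc2)nc2sc(-c3ccco3)nc12` differs from compound 1 in another part of the molecule: pyridin-4-yl in place of thiophen-2-yl on a saturated chain carbon bound to a nitrogen on an aromatic ring. Within the data shown here, no measured step touches this part, so the only guide is that a small change elsewhere already shifted this assay. A modest weakening is expected, a 4.8-fold higher number from compound 1 to compound 3 (0.68 log units; beyond the scatter). Compound 3 is therefore estimated at 60 nM, within 15 nM to 250 nM.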

Compound 3, inhibition constant: 47 nM
The estimate for compound 3 lay 1.3-fold (0.11 log units) above the measured number, within the range that was stated.
By their numbers in this assay, from the lowest: compound 1; then compounds 3 and 2 (each within the scatter of the next).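

Changing the (thiophen-2-yl)methyl group of compound 1 to (pyridin-4-yl)methyl gives, in this assay, a 3.8-fold higher number from compound 1 to compound 3 (0.58 log units; beyond the scatter). This shows that the number responds to the ring at this position, and that a six-membered aromatic ring with a ring nitrogen still leaves compound 3 with a measurable inhibition constant. No available evidence explains this shift.

As far as these compounds go, it remains open how a plain phenyl ring or pyridin-3-yl would compare at this position. From the compounds shown here alone, the effect of a longer chain between the ring and the amine nitrogen also remains open.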